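The compounds below may be only part of what the source reports. "The series", "measured", "known", "first", "only" and "open" are said of these compounds alone.

Compound 1, `FC(F)(F)c1ccccc1-c1nc(NCc2ccccc2)c2ccccc2n1`: 3100 nM in an assay on a protein complex for inhibition of ubiquitin carboxyl-terminal hydrolase 1/WD repeat-containing protein 48 (Homo sapiens), read by fluorescence; a lower number here means a stronger inhibitor, a higher number a weaker inhibitor
Compound 2, `FC(F)(F)c1ccc(CNc2nc(-c3ccccc3C(F)(F)F)nc3ccccc23)cc1`: 8900 nM in this assay
Compound 3, `FC(F)(F)c1ccccc1-c1nc(NCc2ccc(-c3ccc(Cl)cc3)cc2)c2ccccc2n1`: 3600 nM in this assay

Of these three, compound 2 stands with the highest number. Its nearest neighbour is compound 3 and its furthest compound 1: a 2.5-fold lower number from compound 2 to compound 3 (0.39 log units; beyond the scatter), and a 2.9-fold higher number from compound 1 to compound 2 (0.46 log units; beyond the scatter). Both gaps lie beyond the scatter, so compound 2 is the weakest inhibitor of the set.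

Compound 4, `FC(F)(F)c1ccccc1-c1nc(NCc2ccc(-c3cncnc3)cc2)c2ccccc2n1`, is not yet measured. It differs from compound 2 in one place: pyrimidin-5-yl in place of trifluoromethyl on an aromatic carbon.

Within the data shown here, one measured step bears on this directly. The change from compound 2 to compound 3 replaced the same trifluoromethyl with 4-chlorophenyl at the same position, another six-membered aromatic ring, and gave a 2.5-fold lower number from compound 2 to compound 3 (0.39 log units; beyond the scatter). The change from compound 1 to compound 3, adding 4-chlorophenyl where hydrogen stood, gave a 1.2-fold higher number from compound 1 to compound 3 (0.06 log units; within the scatter), within the scatter, while a 2.9-fold higher number from compound 1 to compound 2 (0.46 log units; beyond the scatter) shows that trifluoromethyl at that position raised the number. Taken together, an aromatic ring in place of trifluoromethyl here has so far given a modest lowering, and a step of that size and direction is expected for pyrimidin-5-yl, a 2.2-fold lower number from compound 2 to compound 4 (0.35 log units; beyond the scatter). Compound 4 is therefore estimated at 4000 nM, with a range from 1500 nM to 11000 nM.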

Compound 4, half-maximal inhibitory concentration: 3000 nM
Beside the measured number, compound 4's estimate is 1.3-fold (0.12 log units) above it; the range from low to high includes it.
By their numbers in this assay, from the lowest: compounds 4, 1 and 3 (each within the scatter of the next); then compound 2.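

Pyrimidin-5-yl in place of trifluoromethyl lowered the number (here a 3.0-fold lower number from compound 2 to compound 4 (0.47 log units; beyond the scatter)), so compound 4 joins compound 3 as a second case in which an aromatic ring at this place, para to a large group, gives a lower number than trifluoromethyl does. The make-up of the ring made no readable difference, since exchanging the all-carbon ring of 4-chlorophenyl for a ring with hetero atoms stayed within the scatter (here a 1.2-fold lower number from compound 3 to compound 4 (0.08 log units; within the scatter)), and so did pyrimidin-5-yl in place of hydrogen (here a 1.0-fold lower number from compound 1 to compound 4 (0.01 log units; within the scatter)). In this assay hydrogen, 4-chlorophenyl and pyrimidin-5-yl therefore cannot be told apart at this place, only trifluoromethyl stands apart from them, and nothing measured here accounts for that.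

The compounds shown leave open whether any group at this place can bring the number clearly below that of compound 1, for example an amine, a carboxylic acid or a longer chain. They also leave open whether a ring joined through a different atom, such as piperidin-1-yl, would stay level with the two aromatic rings.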